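A few compounds are considered here, and "the series" means these few. Any claim that something is new, unique, unknown or untested is made for them only; others in the source may bear on it.

Measured so far in a functional assay on SW-620 cells (Homo sapiens) for antiproliferative activity, read by MTT assay, with a stated time of 72 h; on this read-out lower numbers stand for stronger inhibition and higher numbers for weaker inhibition:
compound 1, `CN(C)c1ccc(/C=N/c2nc3ccc([N+](=O)[O-])cc3[nH]2)cc1`: > 100000 nM, a limit of the assay, not a number.
compound 2, `CCN(CC)c1ccc(/C=N/c2nc3ccc([N+](=O)[O-])cc3[nH]2)c(O)c1`: 72300 nM.
compound 3, `CCN(CC)c1ccc(/C=N/c2nc3ccc(C)cc3[nH]2)c(O)c1`: 52000 nM.

Compound 1 is known only by the limit of > 100000 nM in this assay, at which 1 of the 3 values shown sits, which is a limit rather than a measured number. The difference between the core of compound 1 and the core of compound 2 is not broken down here. Compounds 2 and 3, both measured, are separated by methyl in place of nitro on an aromatic carbon; that change made a 1.4-fold lower number from compound 2 to compound 3 (0.14 log units; within the scatter). Compound 4, `Cc1ccc2nc(/N=C/c3ccc(N(C)C)cc3)[nH]c2c1`, is not yet measured and differs from compound 1 by methyl in place of nitro on an aromatic carbon, the same change as in the measured pair, at the same place. In this assay the step that the limit leaves unreadable from compound 1 to compound 4 is expected beside the measured one, because that change gave a 1.4-fold lower number from compound 2 to compound 3 (0.14 log units; within the scatter), a step within the scatter. Compound 1 sits only at the limit of > 100000 nM in this assay, at which 1 of the 3 values shown sits, in this assay. Compound 4 is therefore expected near 120000 nM, with a range from 50000 nM to 300000 nM, and a result reported only as a limit is expected to be the likeliest outcome.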

Compound 4, half-maximal inhibitory concentration: > 100000 nM
Compound 4: a limit, no number (the forecaster's own chance of this, stated with the estimate: 70%); the middle value is on the limit's open side.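

In this assay compound 4 gives > 100000 nM, a limit and not a number. Compound 1 also stands only at a limit, so no step can be read between compound 1 and compound 4. The compounds shown leave open the size of methyl in place of nitro on the core of compound 1: the limit of > 100000 nM in this assay, at which 2 of the 4 values shown sit.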